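The source may hold more compounds than are shown below. What is called first, only, known or untested is meant among the compounds shown, and "the series" means these compounds.

In an ADME assay on Vero cells (Chlorocebus sabaeus) for cytotoxicity, read by MTT assay, with a stated time of 72 h (on this read-out lower numbers stand for higher toxicity in this test and higher numbers for lower toxicity in this test), compound 2 `COC(=O)c1cc(-c2cccc(NC(=O)c3ccc(OCc4ccc(Cl)cc4)cc3)c2)on1` gives > 80 ug/mL, which is a limit and not a number. Compound 1 `COC(=O)c1cc(-c2cccc(NC(=O)c3ccc(C4OC4C(=O)c4ccc(Cl)cc4)cc3)c2)on1` gives > 20 ug/mL, also a limit. For the measured compounds named here, the only measured step is a step that the two limits leave unreadable from compound 1 to compound 2, so it offers no size to carry forward. Compound 3 `COC(=O)c1cc(-c2cccc(NC(=O)c3ccc(/C=C/C(=O)c4cc(F)ccc4F)cc3)c2)on1` differs from compound 2 as follows: 2-((2,5-difluorophenyl)carbonyl)ethenyl in place of (4-chlorobenzyl)oxy on an aromatic carbon. With compound 2 at > 80 ug/mL, any readable change can only be estimated as a move towards lower numbers, and this expectation is loose. The expected step is an at least 2.0-fold lower number from compound 2 to compound 3 (0.30 log units; that floor lies within the scatter). For compound 3 the estimated value is 40 ug/mL, with an expected range of 12 ug/mL to 100 ug/mL.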

Compound 3, half-maximal cytotoxic concentration: > 40 ug/mL
Compound 3: only a limit was reported (the forecaster's own chance of this, stated with the estimate: 50%); the middle value lies on the limit itself.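

For the compounds shown here, compound 1, compound 2 and compound 3 each carry only a limit, so no step among them can be read. The compounds shown leave open the actual half-maximal cytotoxic concentration of each, and whether the three differ at all.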